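Benzyl Replaces Chlorophenyl on the Piperazine Nitrogen

A few compounds are considered here, and "the series" means these few. Any claim that something is new, unique, unknown or untested is made for them only; others in the source may bear on it.

Measured compounds:
compound 1 `Nc1ccccc1NC(=O)c1ccc(CSC(=S)N2CCN(c3ccc(Cl)cc3)CC2)cc1` gives 15%
compound 2 `CCN(Cc1ccncc1)C(=S)SCc1ccc(C(=O)Nc2ccccc2N)cc1` gives 71.6%
compound 3 `Nc1ccccc1NC(=O)c1ccc(CSC(=S)N2CCc3ccc([N+](=O)[O-])cc32)cc1` gives 30.6%

These three compounds share one core and were tested in a functional assay on MGC-803 cells (Homo sapiens) for antiproliferative activity, read by CCK-8 assay, with a stated time of 72 h, tested at 2 uM; on this read-out lower numbers stand for a weaker effect and higher numbers for a stronger effect at the one concentration tested. Compound 1 stands lowest of the three numbers; compound 3 sits higher and compound 2 higher still, both gaps beyond the usual scatter of this assay.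

Compound 4 `Nc1ccccc1NC(=O)c1ccc(CSC(=S)N2CCN(Cc3ccccc3)CC2)cc1` has not yet been measured. Against compound 1 it differs by benzyl in place of 4-chlorophenyl on an amine nitrogen in a ring. Within the data shown here, no measured pair differs in only one place, so nothing measured shows what this single change does on its own. A modest upward step is expected, of the size a number 12 percentage points higher from compound 1 to compound 4 (beyond the scatter), though an outcome within the scatter cannot be ruled out. For compound 4 the expected value is 27%, estimated to lie between 8% and 52%.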

Compound 4, a percentage reported as inhibition, at one concentration (the size of the read-out at that concentration, not a potency): 18.1%
The estimate for compound 4 lay 8.9 percentage points above the measured number; measured number inside the range.
By their numbers in this assay, from the lowest: compounds 1 and 4 (each within the scatter of the next); then compound 3; then compound 2.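

In this assay, among these compounds, benzyl in place of 4-chlorophenyl on the amine nitrogen in a ring gives a number 3.1 percentage points higher from compound 1 to compound 4 (within the scatter), the first comparison in this set that changes only one place. Two groups with the same count of heavy atoms, each holding one six-membered aromatic ring, therefore cannot be told apart at this position. Nothing available explains this outcome. On these data alone, it remains open whether a hydroxyethyl chain or a carboxylic acid on this nitrogen would produce a step beyond the scatter. A methoxy group on the benzyl ring poses the same open question.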